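A second indole arm on a hydroxamic acid chain

The compounds below may be only part of what the source reports. "The series", "measured", "known", "first", "only" and "open" are said of these compounds alone.

Three compounds share a long chain ending in a hydroxamic acid, with an amine nitrogen carrying one aromatic arm. Compound 1 `O=C(CCCCCCNCc1cc2ccccc2[nH]1)NO` has that arm as a (1H-indol-2-yl)methyl. In an assay on cells for inhibition of histone deacetylase 8 (Homo sapiens), read by fluorescence, with a stated time of 24 h (a lower number here means a stronger inhibitor, a higher number a weaker inhibitor), compound 1 gives 620 nM. Compound 2 `O=C(CCCCCCNCc1ccc(-c2ccccc2)s1)NO` gives 550 nM in this assay, a number within the scatter of compound 1, so the two cannot be told apart. Compound 3 `O=C(CCCCCCNCc1ccc([N+](=O)[O-])cc1)NO` gives 2100 nM, a higher number than compound 1 by a margin beyond the scatter, so compound 1 stands as the second highest of the three with compound 2 close beside it.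

Compound 4 `O=C(CCCCCCN(Cc1cc2ccccc2[nH]1)Cc1cc2ccccc2[nH]1)NO` is not yet measured. It differs from compound 1 in a single place: (1H-indol-2-yl)methyl in place of hydrogen on an amine nitrogen. The amine nitrogen thus carries two identical indole arms instead of one arm and a hydrogen. Going by the values given here, no measured pair shows what such a second arm does here, so the expectation rests on the narrow spread seen among compounds 1 and 2 and the absence of any closer guide. For compound 4 the estimate is a step of a 1.5-fold higher number from compound 1 to compound 4 (0.16 log units; within the scatter), toward a somewhat higher number but possibly not beyond the scatter. Compound 4 is therefore expected to give about 900 nM, within a range from 250 nM to 3200 nM.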

Compound 4, half-maximal inhibitory concentration: 4600 nM
The estimate for compound 4 lay 5.1-fold (0.71 log units) below the measured number, and the stated range ends below it.
By their numbers in this assay, from the lowest: compounds 2 and 1 (each within the scatter of the next); then compound 3; then compound 4.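

In this assay, the amine nitrogen proves sensitive to what it carries: putting a second (1H-indol-2-yl)methyl in place of its hydrogen brings a 7.4-fold higher number from compound 1 to compound 4 (0.87 log units; beyond the scatter), so the inhibitor becomes weaker by a margin beyond the scatter. This is the first direct reading of this position among the compounds shown, since the earlier ones differ only in the choice of a single aromatic arm and no pair among them isolates a change on the nitrogen itself. Nothing available here accounts for the loss, and no measurement bears on why the second arm has this effect.

This single step combines two events, the loss of the hydrogen on the amine nitrogen and the arrival of a whole indole arm, and the compounds shown leave open which of the two carries the change. A methyl on the same amine nitrogen would help separate them, as would a second arm of another kind, such as a benzyl, showing whether the result holds only for this indole arm.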